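The source may hold more compounds than are shown below. What is called first, only, known or untested is meant among the compounds shown, and "the series" means these compounds.

Measured compounds:
compound 1 `C=C1CC[C@@H]2[C@](C)(CO[Si](C)(C)C(C)(C)C)[C@H](O)CC[C@@]2(C)[C@@H]1C/C=C1/C(=O)OC[C@H]1OC(C)=O` gives 8.94 uM
compound 2 `C=C1CC[C@@H]2[C@](C)(CO[Si](C)(C)C(C)(C)C)[C@H](O)CC[C@@]2(C)[C@@H]1C/C=C1/C(=O)OC[C@H]1O` gives 17.1 uM

In a functional assay on Col2 cells (Homo sapiens) for cytotoxicity, read by sulforhodamine B assay (a higher number here means that more compound is needed for the effect, a lower number that less compound is needed), compound 2 stands with the higher of the two numbers, but the step of a 1.9-fold higher number from compound 1 to compound 2 (0.28 log units; within the scatter) lies within the scatter, so the two compounds are not told apart. Compound 3 `C=C1CC[C@@H]2[C@](C)(CO[Si](C(C)C)(C(C)C)C(C)C)[C@H](O)CC[C@@]2(C)[C@@H]1C/C=C1/C(=O)OC[C@H]1O` differs from compound 2 in one place: a group of 10 heavy atoms (9 carbon, 1 silicon; no ring) in place of a group of 7 heavy atoms (6 carbon, 1 silicon; no ring), on an oxygen on a saturated carbon. Among the measured compounds shown here, no measured step touches the group on this oxygen; the only known step, a 1.9-fold higher number from compound 1 to compound 2 (0.28 log units; within the scatter), concerns a different oxygen and stayed within the scatter. The step of a 1.0-fold lower number from compound 2 to compound 3 (0.00 log units; within the scatter) is therefore expected to stay within the scatter. Compound 3 is estimated at 17 uM, within 6 uM to 50 uM.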

Compound 3, concentration for half-maximal effect: 2.73 uM
Estimate against measurement, compound 3: 6.2-fold (0.79 log units) above; the whole stated range lies above it.
By their numbers in this assay, from the lowest: compound 3; then compounds 1 and 2 (each within the scatter of the next).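

In this assay, the group on this oxygen on a saturated carbon clearly matters: replacing the group of 7 heavy atoms with the group of 10 heavy atoms gives a real change (a 6.3-fold lower number from compound 2 to compound 3 (0.80 log units; beyond the scatter)). The earlier change on a different oxygen did not separate its pair (a 1.9-fold higher number from compound 1 to compound 2 (0.28 log units; within the scatter)). Among the compounds shown here, this is the first sign that the number responds to what sits on this oxygen. Nothing available accounts for the step.

On these data alone, whether silicon itself is needed remains open, as does what a free hydroxyl, a benzyl group or a longer chain on this oxygen would do.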